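Piperidine in place of thiosemicarbazide on the pyrimidine amine

The source may report more compounds than this note shows. Statements on the series, on what has been measured and on what is new or still open speak of the compounds shown alone.

Measured so far:
Compound 1 `Cc1ccc(Nc2cc(C)nc(SCc3nc4ccccc4[nH]3)n2)cc1`: in a functional assay on MGC-803 cells (Homo sapiens) for cytotoxicity, read by MTT assay, with a stated time of 72 h (on this read-out lower numbers stand for stronger inhibition and higher numbers for weaker inhibition), compound 1 gives 7390 nM.
Compound 2 `Cc1cc(NC(C)C)nc(SCc2nc3ccccc3[nH]2)n1`: in this assay compound 2 gives only a limit, > 100000 nM.
Compound 3 `Cc1cc(NNC(N)=S)nc(SCc2nc3ccccc3[nH]2)n1`: in this assay compound 3 likewise gives only a limit, > 100000 nM.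

Compound 3 therefore stands at the limit of > 100000 nM in this assay, at which 2 of the 3 values shown sit, where compound 2 also sits; only compound 1 has a real number. Compound 4 `Cc1cc(N2CCCCC2)nc(SCc2nc3ccccc3[nH]2)n1` differs from compound 3 in one place: a group of 6 heavy atoms (5 carbon, 1 nitrogen; one six-membered non-aromatic ring with 1 hetero atom) in place of a group of 5 heavy atoms (1 carbon, 3 nitrogen, 1 sulfur; no ring), on an aromatic carbon. Among the measured compounds shown here, the steps that bear on this are an at least 13-fold higher number from compound 1 to compound 2 (1.13 log units; beyond the scatter) and an at least 13-fold higher number from compound 1 to compound 3 (1.13 log units; beyond the scatter); in both, removing the 4-methylphenyl from the ring nitrogen pushed the value to the limit. The step that the two limits leave unreadable from compound 2 to compound 3 gives no size. Compound 4 also lacks an aromatic ring on that nitrogen, so the step of an at least 1.2-fold lower number from compound 3 to compound 4 (0.09 log units; that floor lies within the scatter) is expected to be small or unreadable. Compound 4 is expected to give 80000 nM, between 20000 nM and 300000 nM.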

Compound 4, half-maximal inhibitory concentration: > 100000 nM
Compound 4 gave a limit, no number; the forecaster's own chance of this, stated with the estimate: 60%; middle value at least 1.2-fold (0.09 log units) from the limit.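

Putting piperidin-1-yl in place of (4-methylphenyl)amino gives an at least 13-fold higher number from compound 1 to compound 4 (1.13 log units; beyond the scatter) in this assay. A ring on this aromatic carbon is therefore not enough on its own: among the compounds shown, only compound 1, with its aromatic ring on the nitrogen, has a real number. The steps to compound 4 from compound 2 and from compound 3 cannot be read, and all three now share one mark: the limit of > 100000 nM in this assay, at which 3 of the 4 values shown sit.

Still open, going by these compounds, is how much of compound 1's activity depends on the methyl on its aromatic ring or on the nitrogen hydrogen. A phenylamino or an N-methyl-N-phenylamino group on this carbon would separate these.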